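The compounds below may be only part of what the source reports. "The series", "measured", "known", "first", "only" and "open" are said of these compounds alone.

Values in an ADME assay on L02 cells (Homo sapiens) for antiproliferative activity, read by MTT assay, with a stated time of 48 h (on this read-out lower numbers stand for stronger inhibition and higher numbers for weaker inhibition), for the measured members of the series:
Compound 1, `Cc1ccccc1-n1nncc1CN1C(=O)C2(C(C#N)=C(N)Oc3c2c2nc4ccccc4nc2c2ccccc32)c2ccccc21`, gives > 50000 nM, which is a limit of the assay.
Compound 2, `N#CC1=C(N)Oc2c(c3nc4ccccc4nc3c3ccccc23)C12C(=O)N(Cc1cnnn1-c1cccc(Cl)c1)c1ccccc12`, gives 35200 nM.
Compound 3, `CCc1ccccc1-n1nncc1CN1C(=O)C2(C(C#N)=C(N)Oc3c(N)cc4nc5ccccc5nc4c32)c2ccccc21`, gives 22900 nM.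

Compound 3 and compound 2 sit within the scatter of each other, and the third value shown is a limit, so compound 3 cannot be ranked against the others on these numbers. Compound 4, `Cc1ccc(Cl)cc1-n1nncc1CN1C(=O)C2(C(C#N)=C(N)Oc3c(N)cc4nc5ccccc5nc4c32)c2ccccc21`, is not yet measured. It differs from compound 3 by 5-chloro-2-methylphenyl in place of 2-ethylphenyl on an aromatic nitrogen. Among the compounds with values here, the one measured step, an at least 1.4-fold lower number from compound 1 to compound 2 (0.15 log units; that floor lies within the scatter), also exchanges the aryl group on the aromatic nitrogen; its size is bounded only by the limit (the limit of > 50000 nM in this assay, at which 1 of the 3 values shown sits), and its floor lies within the scatter. An aryl exchange at this nitrogen has so far given no step beyond the scatter, and none beyond the scatter is expected in this assay for the step of a 1.0-fold lower number from compound 3 to compound 4 (0.02 log units; within the scatter). Compound 4 is therefore expected to give 22000 nM, estimated between 9000 nM and 50000 nM.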

Compound 4, half-maximal inhibitory concentration: > 50000 nM
Compound 4: only a limit was reported; the forecaster's own chance of this, stated with the estimate: 20%; at least 2.2-fold (0.35 log units) between middle value and limit.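

In this assay, within the data shown here, 5-chloro-2-methylphenyl in place of 2-ethylphenyl on the aromatic nitrogen gives an at least 2.1-fold higher number from compound 3 to compound 4 (0.33 log units; beyond the scatter), the first aryl exchange at this position with a step beyond the scatter. Among these compounds, the only earlier exchange here, an at least 1.4-fold lower number from compound 1 to compound 2 (0.15 log units; that floor lies within the scatter), runs towards a lower number and has a floor within the scatter, so the aryl group at this nitrogen can now be said to matter in this read-out, at least between compound 3 and compound 4. Compound 4 gives > 50000 nM, which is a limit, so only the floor of the step can be read, and this end of the series is now poorly resolved: the limit of > 50000 nM in this assay, at which 2 of the 4 values shown sit.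

On these data alone, the exchange adds chlorine and shortens ethyl to methyl at once, so which of the two carries the step stays open. As far as these compounds go, how an amine or a carboxylic acid on this phenyl ring would read in this assay also stays open.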